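The source may report more compounds than this note shows. Statements on the series, on what has been measured and on what is new or still open speak of the compounds shown alone.

Compound 2 `CCS(=O)(=O)c1ccccc1Cc1c2c(n(CC(=O)O)c1C)CCNC2=O` gives the higher of the two numbers in a functional assay on CHO.K1 cells for antagonist activity at prostaglandin D2 receptor 2 (Homo sapiens), read by GTPgammaS binding, with a stated time of 1 h (on this read-out lower numbers stand for stronger inhibition and higher numbers for weaker inhibition), at 550 nM. Compound 1 `COc1cccc(S(=O)(=O)c2ccccc2Cc2c3c(n(CC(=O)O)c2C)CCNC3=O)c1` gives 12 nM, and the step of a 46-fold higher number from compound 1 to compound 2 (1.66 log units; beyond the scatter) shows how much weaker the inhibition became when ethyl replaced 3-methoxyphenyl on the sulfonyl sulfur. Compound 3 `Cc1c(Cc2ccccc2S(=O)(=O)C2CCCCC2)c2c(n1CC(=O)O)CCNC2=O` carries the change cyclohexyl in place of ethyl on a sulfonyl sulfur: a ring returns to that sulfonyl sulfur, though a non-aromatic one of carbon only, so part of the difference between compound 1 and compound 2 may come back. Compound 3 is therefore expected to give a lower number in this assay, a step of a 6.9-fold lower number from compound 2 to compound 3 (0.84 log units; beyond the scatter), with an estimate of 80 nM and a likely range from 25 nM to 300 nM.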

Compound 3, half-maximal inhibitory concentration: 28 nM
The estimate for compound 3 lay 2.9-fold (0.46 log units) above the measured number, within the range that was stated.
By their numbers in this assay, from the lowest: compound 1; then compound 3; then compound 2.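

In this assay, the sulfonyl sulfur does not need an aromatic ring for most of the activity: the step with cyclohexyl in place of ethyl is large (a 20-fold lower number from compound 2 to compound 3 (1.29 log units; beyond the scatter)). Cyclohexyl does not fully match 3-methoxyphenyl, however, leaving a modest gap (a 2.3-fold higher number from compound 1 to compound 3 (0.37 log units; beyond the scatter)). No measured evidence here gives a reason for either step.

Still open, going by these compounds, is whether a ring is needed at all, or whether a longer chain such as n-hexyl would serve as well. A smaller ring such as cyclopropyl, or a plain phenyl, also remains untested among the compounds shown.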